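Ester to primary amide on the shared core

The source may report more compounds than this note shows. Statements on the series, on what has been measured and on what is new or still open speak of the compounds shown alone.

For the measured compounds named here, compound 2 `COC(=O)c1ccccc1SC/C=C(\C)CC/C=C(\C)CCC=C(C)C` stands at the lower of the two numbers so far in a functional assay on U-87MG ATCC cells (Homo sapiens) for cytotoxicity, with a stated time of 7 days (on this read-out lower numbers stand for stronger inhibition and higher numbers for weaker inhibition), 10000 nM, within the scatter of compound 1 `CNC(=O)c1ccccc1SC/C=C(\C)CC/C=C(\C)CCC=C(C)C`, which gives 18000 nM. Compound 3 `CC(C)=CCC/C(C)=C/CC/C(C)=C/CSc1ccccc1C(N)=O` differs from compound 2 by amino in place of methoxy on a carbonyl carbon. Going by the values given here, the only step bearing on this change is the exchange at the same carbonyl carbon, a 1.8-fold lower number from compound 1 to compound 2 (0.26 log units; within the scatter), which is too small to point in either direction. No step beyond the scatter is therefore expected, a 1.2-fold higher number from compound 2 to compound 3 (0.08 log units; within the scatter). Compound 3 is estimated at 12000 nM in this assay, within 5000 nM to 30000 nM.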

Compound 3, half-maximal inhibitory concentration: 10000 nM
Compound 3: the middle estimate sits 1.2-fold (0.08 log units) above what was measured; the range from low to high includes it.
By their numbers in this assay, from the lowest: compounds 2, 3 and 1 (each within the scatter of the next).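

In this assay the carbonyl carbon now carries methoxy, methylamino or amino, with no change at the digits printed from compound 2 to compound 3 (within the scatter) for amino in place of methoxy and a 1.8-fold lower number from compound 1 to compound 3 (0.26 log units; within the scatter) for hydrogen in place of methyl on the amide-type nitrogen. Neither the exchange of ester for primary amide nor the methyl on the amide-type nitrogen separates these compounds at this position.

As far as these compounds go, a carboxylic acid or a dimethylamino group at this carbonyl carbon remains open, as does a shorter chain on the shared core. No evidence is available to explain these results.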